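The compounds below may be only part of what the source reports. "The series", "measured", "known", "first", "only" and "open" are said of these compounds alone.

Measured compounds in a functional assay on cells (Splenocyte, Mus musculus, strain BALB/c) for inhibition, read by scintillation counting and thymidine incorporation, with stated times of 48 h and 8 h; a higher number here means a weaker inhibitor, a lower number a stronger inhibitor:

- Compound 1, `COc1cc(-c2noc(-c3ccccc3)n2)cc(OC)c1OC`: compound 1 gives > 50000 nM, a limit of the assay rather than a number.
- Compound 2, `COc1cc(-c2noc(-c3ccc(NC(=O)OC(C)(C)C)cc3)n2)cc(OC)c1OC`: compound 2 gives 2200 nM.
- Compound 3, `CCCCc1ccc(-c2nc(-c3cc(OC)c(OC)c(OC)c3)no2)cc1`: compound 3 gives 36200 nM.

Compound 3 holds the highest of the two numbers; its nearest neighbour is compound 2, with a 16-fold higher number from compound 2 to compound 3 (1.22 log units; beyond the scatter). Against compound 1, whose result is only a limit (the limit of > 50000 nM in this assay, at which 1 of the 3 values shown sits), the step is an at least 1.3-fold lower number from compound 1 to compound 3 (0.14 log units; that floor lies within the scatter), so the butyl in place of hydrogen may have changed nothing.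

Compound 4, `CCCCCCc1ccc(-c2nc(-c3cc(OC)c(OC)c(OC)c3)no2)cc1`, has not been measured. It differs from compound 3 by ethyl in place of hydrogen on a saturated chain carbon, four bonds along the chain from an aromatic carbon.

Going by the values given here, two measured steps touch the same aromatic position. The step of a 16-fold higher number from compound 2 to compound 3 (1.22 log units; beyond the scatter) is large but swaps an entirely different group, (tert-butoxycarbonyl)amino, for butyl, so it says little about lengthening the chain. The step of an at least 1.3-fold lower number from compound 1 to compound 3 (0.14 log units; that floor lies within the scatter) adds four chain carbons where hydrogen stood and stays within the scatter. Extending that chain by ethyl is therefore expected to give a step of the order of a 1.0-fold lower number from compound 3 to compound 4 (0.01 log units; within the scatter), not beyond the scatter, in either direction. Compound 4 is estimated at 35000 nM, with the range 12000 nM to 100000 nM, and a real chance that this assay again returns only a limit.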

Compound 4, half-maximal inhibitory concentration: 22900 nM
The estimate for compound 4 lay 1.5-fold (0.18 log units) above the measured number; the range from low to high includes it.
By their numbers in this assay, from the lowest: compound 2; then compounds 4 and 3 (each within the scatter of the next). At a limit, above all of these: compound 1.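

In this assay, ethyl in place of hydrogen on a saturated chain carbon, four bonds along the chain from an aromatic carbon, gives a 1.6-fold lower number from compound 3 to compound 4 (0.20 log units; within the scatter), so compound 3 and compound 4 cannot be told apart and this extension of the chain has no resolved effect. Compound 1 stands only as a limit of the assay, yet an at least 2.1-fold lower number from compound 1 to compound 4 (0.33 log units; beyond the scatter) has a floor that clears the scatter, which the butyl step did not, so hexyl is the first alkyl chain here shown to differ from hydrogen on that aromatic carbon, though the size of that difference stays unknown: the limit of > 50000 nM in this assay, at which 1 of the 4 values shown sits. Hexyl still falls well short of (tert-butoxycarbonyl)amino, with a 10-fold higher number from compound 2 to compound 4 (1.02 log units; beyond the scatter), so across these compounds neither alkyl chain matches compound 2.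

Going by these compounds, whether a longer chain such as octyl would separate from hexyl remains open. Also open, on these data alone, is whether a free amine or a carboxylic acid on that aromatic carbon would keep the number of compound 2, or whether that number needs the whole (tert-butoxycarbonyl)amino group.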